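Hydroxy to methoxy: a second pair in the series

This account rests on a few compounds, and the source may have more. Where it says the series, first, only, none or still open, it means among the compounds named here.

Compound 1 `O=C(Nc1cccc(-n2cc(-c3ccncc3)c(-c3cc(O)cc(Cl)c3)n2)c1)Nc1ccc(Cl)c(Cl)c1` and compound 2 `COc1cc(Cl)cc(-c2nn(-c3cccc(NC(=O)Nc4ccc(Cl)c(Cl)c4)c3)cc2-c2ccncc2)c1` form the first matched pair. In a functional assay on SK-OV-3 cells (Homo sapiens) for inhibition, read by sulforhodamine B assay, with a stated time of 48 h, tested at 10 uM (a lower number here means a stronger effect, a higher number a weaker effect of the compound at the concentration tested), compound 1 gives 13.2% and compound 2 gives 14.2%. The structural difference between them is methyl in place of hydrogen on an oxygen on an aromatic ring, and the step it made is a number 1 percentage points higher from compound 1 to compound 2 (within the scatter). Compound 3 `O=C(Nc1cccc(-n2cc(-c3ccncc3)c(-c3cc(O)cc(Cl)c3)n2)c1)c1cc(C(F)(F)F)cc(C(F)(F)F)c1` rests on another core; the difference between the core of compound 3 and the core of compound 1 is not broken down here. In this assay compound 3 gives 68.9%, the highest of the three numbers, lying beyond the scatter from both compound 1 and compound 2. Compound 4 `COc1cc(Cl)cc(-c2nn(-c3cccc(NC(=O)c4cc(C(F)(F)F)cc(C(F)(F)F)c4)c3)cc2-c2ccncc2)c1` has not yet been measured. It differs from compound 3 by methyl in place of hydrogen on an oxygen on an aromatic ring, the same change as in the first pair, at a place described in the same words. Given that the earlier step of a number 1 percentage points higher from compound 1 to compound 2 (within the scatter) stayed within the scatter, the expected step here is a number 1.1 percentage points higher from compound 3 to compound 4 (within the scatter). Compound 4 is therefore estimated at 70% in this assay, within a range from 55% to 85%.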

Compound 4, a percentage reported as activity, at one concentration (the size of the read-out at that concentration, not a potency): 83.4%
For compound 4 the middle estimate is 13.4 percentage points below the measured one; low and high end bracket the measured number.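

On the core of compound 3, hydroxy to methoxy in this assay gives a number 14.5 percentage points higher from compound 3 to compound 4 (beyond the scatter) and so a weaker effect at the concentration tested, whereas the same change on the core of compound 1 gives a number 1 percentage points higher from compound 1 to compound 2 (within the scatter) and no change that can be told from the scatter. Although only the second step lies beyond the scatter, the two steps themselves cannot be told apart: the same change on two cores in this assay, a number 1 percentage points higher (within the scatter) from compound 1 to compound 2 and a number 14.5 percentage points higher (beyond the scatter) from compound 3 to compound 4, 13.5 percentage points apart, within the scatter of two such steps

For the compounds shown here, the two pairs therefore give no ground for saying that the change behaves differently on the two cores, yet they do not establish that it carries over with a constant size, and with only two pairs the reading extends no further than these four compounds.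

As far as these compounds go, what an ethyl or a longer chain on that oxygen would do on either core stays open, as does the effect of an amine or a carboxylic acid in place of the hydroxy group. Each compound is described here by a read-out at one concentration, and the comparison speaks only of a stronger or weaker effect at that concentration.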